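A few compounds are considered here, and "the series" means these few. Any claim that something is new, unique, unknown or untested is made for them only; others in the source may bear on it.

Measured in a functional assay on HepG2 cells (Homo sapiens) for antiproliferative activity, read by MTT assay, with a stated time of 72 h; a lower number here means a stronger inhibitor, a higher number a weaker inhibitor:
- Compound 1 `O=C1COc2ccc(-c3cccc(NS(=O)(=O)c4ccc(F)cc4)c3)cc2N1`: > 40000 nM
- Compound 2 `COc1ccc(N2C(=O)COc3ccc(-c4ccc(O)cc4)cc32)cc1`: 10800 nM
- Compound 3 `COc1ncc(-c2ccc3c(c2)N(c2ccccc2)C(=O)CO3)cc1NS(=O)(=O)c1ccc(F)cc1`: 14000 nM

Compound 1 stands at the limit of > 40000 nM in this assay, at which 1 of the 3 values shown sits, so its result is a limit and not a number. Compound 4 `O=C1COc2ccc(-c3cccc(NS(=O)(=O)c4ccc(F)cc4)c3)cc2N1c1ccc(Cl)cc1` has one change from compound 1: 4-chlorophenyl in place of hydrogen on an amide-type nitrogen in a ring, with 4-chlorophenyl in place of hydrogen on an amide-type nitrogen in a ring. Within the data shown here, no two measured compounds differ in only one place, so the only guide is loose. Compound 2 at 10800 nM and compound 3 at 14000 nM also carry an aromatic ring on that nitrogen, though both differ from compound 1 elsewhere too. A moderate gain in this assay is therefore expected, estimated as an at least 3.3-fold lower number from compound 1 to compound 4 (0.52 log units; beyond the scatter). For compound 4 the expected value is 12000 nM, with an estimated range from 3500 nM to 40000 nM.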

Compound 4, half-maximal inhibitory concentration: 27800 nM
For compound 4 the middle estimate is 2.3-fold (0.36 log units) below the measured one; the measured number falls inside the stated range.
By their numbers in this assay, from the lowest: compounds 2, 3 and 4 (each within the scatter of the next, the first and the last beyond it). At a limit, above all of these: compound 1.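

In this assay, among these compounds, compound 4 gives a comparison that differs in one place at this position, the amide-type nitrogen in a ring, which the earlier compounds did not allow. Placing 4-chlorophenyl there in place of hydrogen gives an at least 1.4-fold lower number from compound 1 to compound 4 (0.15 log units; that floor lies within the scatter). Compound 1 is known only as a limit, so the true size of this step cannot be read, because the starting point is not a number: the limit of > 40000 nM in this assay, at which 1 of the 4 values shown sits.

What the compounds shown leave open is how a small group such as methyl, or a longer chain ending in an amine, would behave on this nitrogen.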